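Series notes: chlorobenzyl placement in the triazole thioether set

The compounds below may be only part of what the source reports. "The series", "measured", "known", "first", "only" and "open" are said of these compounds alone.

Measured compounds:
compound 1 `COc1ccccc1Nc1nc(SCc2cn(Cc3ccccc3Cl)nn2)nc(-c2ccccc2)c1C#N`, compound 1 gives 5800 nM in a functional assay on MGC-803 cells (Homo sapiens) for inhibition, read by MTT assay, with a stated time of 72 h; on this read-out lower numbers stand for stronger inhibition and higher numbers for weaker inhibition
compound 2 `Cc1ccc(Nc2nc(SCc3cn(Cc4ccc(Cl)cc4)nn3)nc(-c3ccccc3)c2C#N)cc1`, compound 2 gives 19600 nM in this assay

Compound 2 stands at the highest of the two numbers in this assay; compound 1 is the nearest, and its lower number lies beyond the usual scatter. Compound 1 and compound 2 differ in two places, so no single step can be read between them.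

Compound 3 `Cc1ccc(Nc2nc(SCc3cn(Cc4ccccc4Cl)nn3)nc(-c3ccccc3)c2C#N)cc1` differs from compound 2 in one place: 2-chlorophenyl in place of 4-chlorophenyl on a saturated chain carbon bound to an aromatic nitrogen. Compound 3 thus carries the same 2-chlorobenzyl on the triazole as compound 1 while keeping the aniline part of compound 2. Going by the values given here, the set holds no pair that isolates this change, so its effect is not known. Among the compounds with values here, the only compound with 2-chlorobenzyl, compound 1, gives 5800 nM, but the second difference to compound 2 leaves the cause of that gap open.

A modest downward step a 1.8-fold lower number from compound 2 to compound 3 (0.25 log units; within the scatter) is expected, uncertain in size and possibly within the scatter. Compound 3 is estimated at 11000 nM in this assay, with a range from 4500 nM to 27000 nM.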

Compound 3, half-maximal inhibitory concentration: 7190 nM
The estimate for compound 3 lay 1.5-fold (0.18 log units) above the measured number; the measured number falls inside the stated range.
By their numbers in this assay, from the lowest: compounds 1 and 3 (each within the scatter of the next); then compound 2.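

In this assay, going by these compounds alone, 2-chlorophenyl in place of 4-chlorophenyl on a saturated chain carbon bound to an aromatic nitrogen gives a 2.7-fold lower number from compound 2 to compound 3 (0.44 log units; beyond the scatter), the first reading of the chlorine placement with the rest of the structure held constant, and it places the 2-chlorobenzyl form on the lower side of the scatter-exceeding gap. With 2-chlorobenzyl held constant, 4-methylphenyl in place of 2-methoxyphenyl on a nitrogen on an aromatic ring gives a 1.2-fold higher number from compound 1 to compound 3 (0.09 log units; within the scatter), so this pair shows no separation beyond the scatter and the two aniline groups cannot be told apart here. No supporting data bear on the origin of either step.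

The compounds shown leave open whether the change from 4-chlorobenzyl to 2-chlorobenzyl has a similar size when 2-methoxyphenyl, rather than 4-methylphenyl, sits on the nitrogen on an aromatic ring. They also leave open how an unsubstituted benzyl group, or a bromine or methoxy group in place of the chlorine, would read in this assay on the same core.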